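Compound 3: one group swapped on an amine nitrogen

The compounds below may be only part of what the source reports. "The series", "measured", "known", "first", "only" and "open" are said of these compounds alone.

- Compound 1 `CCOC(=O)C1=C(N/C=N/c2cccnc2Cl)Nc2[nH]nc(C)c2C1c1ccc(N(C)C)cc1` in a functional assay on HepG2 cells (Homo sapiens) for inhibition, read by MTT assay, with a stated time of 48 h (on this read-out lower numbers stand for stronger inhibition and higher numbers for weaker inhibition), gives 4890 nM
- Compound 2 `CCOC(=O)C1=C(NN=C(C#N)C#N)Nc2[nH]nc(C)c2C1c1ccc(N(C)C)cc1` in this assay gives 13700 nM

Compound 2 has the higher of the two numbers (13700 nM) and so the weaker inhibition of the pair. Compound 3 `CCOC(=O)C(=NNC1=C(C(=O)OCC)C(c2ccc(N(C)C)cc2)c2c(C)n[nH]c2N1)C(=O)OCC` alters one group of compound 2 on an amine nitrogen (a group of 12 heavy atoms (7 carbon, 1 nitrogen, 4 oxygen; no ring) in place of a group of 6 heavy atoms (3 carbon, 3 nitrogen; no ring), on an amine nitrogen). For the measured compounds named here, only one measured step bears on this change: a 2.8-fold higher number from compound 1 to compound 2 (0.45 log units; beyond the scatter), a modest step beyond the scatter. There the smaller group came with the higher number, but the larger group in that pair carries a ring, and the group entering here has none. A single step like this is weak guidance. In this assay a small move to a lower number is expected for compound 3 (a 1.7-fold lower number from compound 2 to compound 3 (0.23 log units; within the scatter)), smaller than that measured step. The estimated value for compound 3 is 8000 nM, with an expected range from 2500 nM to 26000 nM as its limits.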

Compound 3, half-maximal inhibitory concentration: 80800 nM
Compound 3: the middle estimate sits 10-fold (1.00 log units) below what was measured; measured number above the stated range.
By their numbers in this assay, from the lowest: compound 1; then compound 2; then compound 3.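

In this assay, a larger group without a ring on this amine nitrogen goes with weaker inhibition, giving a 5.9-fold higher number from compound 2 to compound 3 (0.77 log units; beyond the scatter) in the swap of the smaller group for the larger one. Set against the ring-bearing group, the same entering group gives a 17-fold higher number from compound 1 to compound 3 (1.22 log units; beyond the scatter), so the position clearly responds to what it carries, yet size alone does not order the three compounds: compound 1 has the lowest number despite a larger group than compound 2. Nothing measured here explains these differences.

Going by these compounds, it remains open whether the ring or its chlorine goes with the lower number of compound 1, which a plain phenyl ring would test. A short ethyl chain on this nitrogen would show how a small group without nitrile or carbonyl groups compares.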